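This account rests on a few compounds, and the source may have more. Where it says the series, first, only, none or still open, it means among the compounds named here.

Three compounds have been measured in a functional assay for inhibition, tested at 100 uM; a lower number here means less inhibition, a higher number more inhibition at the concentration tested (going by the name of the read-out):

Compound 1, `Cc1ccc(S(=O)(=O)/C=C/S(=O)(=O)CC2=NCCS2)cc1`: 21.7%
Compound 2, `Cc1ccc(S(=O)(=O)/C=C/S(=O)(=O)CC2=NCCO2)cc1`: 74.2%
Compound 3, `O=S(=O)(CC1=NCCO1)c1c[nH]cc1S(=O)(=O)c1ccc(Cl)cc1`: 92.1%

Compound 2 and compound 1 share a core and differ in one place: a group of 5 heavy atoms (3 carbon, 1 nitrogen, 1 sulfur; one five-membered non-aromatic ring with 2 hetero atoms) in place of a group of 5 heavy atoms (3 carbon, 1 nitrogen, 1 oxygen; one five-membered non-aromatic ring with 2 hetero atoms), on a saturated chain carbon bound to a sulfonyl sulfur. This change brought a number 52.5 percentage points lower from compound 2 to compound 1 (beyond the scatter).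

Compound 3 has a different core; how it differs from compound 2 is not broken down here. In this assay compound 3 gives the highest of the three numbers, and its gap to compound 2 and to compound 1 is beyond the scatter.

Compound 4, `O=S(=O)(CC1=NCCS1)c1c[nH]cc1S(=O)(=O)c1ccc(Cl)cc1`, has not yet been measured. It stands to compound 3 as compound 1 stands to compound 2: a group of 5 heavy atoms (3 carbon, 1 nitrogen, 1 sulfur; one five-membered non-aromatic ring with 2 hetero atoms) in place of a group of 5 heavy atoms (3 carbon, 1 nitrogen, 1 oxygen; one five-membered non-aromatic ring with 2 hetero atoms), on a saturated chain carbon bound to a sulfonyl sulfur. The place is the same in both pairs, so this is the same change.

If the change acts on this core as it did on the core of compound 2, compound 4 is expected to fall well below compound 3, with an estimated step of a number 47.1 percentage points lower from compound 3 to compound 4 (beyond the scatter), resting on the single earlier step of a number 52.5 percentage points lower from compound 2 to compound 1 (beyond the scatter). That step was observed once only, so the expectation is loose: compound 4 is estimated at 45%, between 20% and 75%.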

Compound 4, a percentage reported as inhibition, at one concentration (the size of the read-out at that concentration, not a potency): 41.4%
Estimate against measurement, compound 4: 3.6 percentage points above; the measured number falls inside the stated range.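

Swapping the oxygen-containing five-membered ring for the sulfur-containing one gave, in this assay, a number 50.7 percentage points lower from compound 3 to compound 4 (beyond the scatter). The same swap on the core of compound 2 had a matching effect, so in these two pairs the size of the drop carried over from one core to the other: the same change on two cores in this assay, a number 52.5 percentage points lower (beyond the scatter) from compound 2 to compound 1 and a number 50.7 percentage points lower (beyond the scatter) from compound 3 to compound 4, 1.8 percentage points apart, within the scatter of two such steps

Among the compounds shown here, this shows that the change behaved alike on two cores, but it does not show that it would do so on a third core, and it does not explain why the sulfur-containing group gives less inhibition, since each compound has only a single reading at one concentration rather than a potency.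

As far as these compounds go, it remains open how other groups on the saturated chain carbon bound to a sulfonyl sulfur would fare, such as an amine, a carboxylic acid or a longer chain. Also open, from the compounds shown here alone, is whether the same drop would appear in a full concentration series.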